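Trading a hydroxyl-bearing alkyne chain for a plain hexyl chain

The source may hold more compounds than are shown below. What is called first, only, known or untested is meant among the compounds shown, and "the series" means these compounds.

Compound 3 `O=c1[nH]c(=O)n([C@H]2C[C@H](O)[C@@H](CO)O2)cc1C#CCCCO` gives 280 ug/mL in a functional assay on L1210 cells (Mus musculus) (on this read-out lower numbers stand for stronger inhibition and higher numbers for weaker inhibition), the higher of the two plain numbers shown, with compound 1 `COCC#Cc1cn([C@H]2C[C@H](O)[C@@H](CO)O2)c(=O)[nH]c1=O` close by at 254 ug/mL, a gap within the scatter. Compound 2 `CCC#Cc1cn([C@H]2C[C@H](O)[C@@H](CO)O2)c(=O)[nH]c1=O` reaches only the limit of > 1000 ug/mL. Compound 4 `CCCCCCc1cn([C@H]2C[C@H](O)[C@@H](CO)O2)c(=O)[nH]c1=O` differs from compound 3 by hexyl in place of 5-hydroxypent-1-yn-1-yl on an aromatic carbon. Within the data shown here, two measured steps bear on this change. Removing the chain oxygen gave an at least 3.9-fold higher number from compound 1 to compound 2 (0.59 log units; beyond the scatter), and adding a hydroxymethyl gave an at least 3.5-fold lower number from compound 2 to compound 3 (0.55 log units; beyond the scatter). Compound 4 likewise loses the chain oxygen, and the triple bond as well, so a weaker result is expected, a step of a 3.6-fold higher number from compound 3 to compound 4 (0.55 log units; beyond the scatter), quite possibly ending at the limit (the limit of > 1000 ug/mL in this assay, at which 1 of the 3 values shown sits). Compound 4 is therefore estimated at 1000 ug/mL, between 300 ug/mL and 3000 ug/mL.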

Compound 4, concentration for 50% inhibition: 301 ug/mL
Compound 4: the middle estimate sits 3.3-fold (0.52 log units) above what was measured; measured number inside the range.
By their numbers in this assay, from the lowest: compounds 1, 3 and 4 (each within the scatter of the next). At a limit, above all of these: compound 2.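

In this assay the hexyl chain holds level with the oxygen-bearing chains, with a 1.1-fold higher number from compound 3 to compound 4 (0.03 log units; within the scatter) and a 1.2-fold higher number from compound 1 to compound 4 (0.07 log units; within the scatter) in the same range. On this aromatic carbon, then, neither a chain oxygen nor a triple bond is needed to reach numbers of this size, so losing the oxygen does not by itself lead to the result for compound 2. Hexyl in place of but-1-yn-1-yl gives an at least 3.3-fold lower number from compound 2 to compound 4 (0.52 log units; beyond the scatter) in a step that starts from a limit: the limit of > 1000 ug/mL in this assay, at which 1 of the 4 values shown sits. Still open, as far as these compounds go, is how an octyl chain, or a chain carrying an amine or a carboxylic acid, would read on this aromatic carbon.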